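The compounds below may be only part of what the source reports. "The series", "measured", "known", "first", "only" and "open" are said of these compounds alone.

Measured in a functional assay on SMMC-7721 cells (Homo sapiens) for cytotoxicity, read by MTT assay, with a stated time of 24 h (a lower number here means a stronger inhibitor, a higher number a weaker inhibitor), so far:
Compound 1 `O=C1/C(=C/c2ccncc2)CN(S(=O)(=O)c2ccccc2)C/C1=C\c1ccccc1C(F)(F)F` gives 6540 nM
Compound 2 `Cc1ccc(S(=O)(=O)N2C/C(=C\c3ccncc3)C(=O)/C(=C/c3ccccc3C(F)(F)F)C2)cc1` gives 5590 nM
Compound 3 `O=C1/C(=C/c2ccncc2)CN(S(=O)(=O)c2ccc(C(F)(F)F)cc2)C/C1=C\c1ccccc1C(F)(F)F` gives 3840 nM

On these numbers compound 3 cannot be separated from the other two, since its value lies within the scatter of both. Compound 4 `O=C1/C(=C/c2ccncc2)CN(S(=O)(=O)c2ccc(F)cc2)C/C1=C\c1ccccc1C(F)(F)F` differs from compound 3 by fluoro in place of trifluoromethyl on an aromatic carbon and carries fluoro in place of trifluoromethyl on an aromatic carbon. The steps of a 1.2-fold lower number from compound 1 to compound 2 (0.07 log units; within the scatter) and a 1.7-fold lower number from compound 1 to compound 3 (0.23 log units; within the scatter) and a 1.5-fold lower number from compound 2 to compound 3 (0.16 log units; within the scatter) bear on this change, all at that same place and all small. So no step beyond the scatter is expected in this assay and no direction is favoured. The estimated step is a 1.3-fold higher number from compound 3 to compound 4 (0.10 log units; within the scatter) and it is expected to stay small. For compound 4 the estimated value is 4800 nM with an expected range of 2800 nM to 8000 nM in this assay.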

Compound 4, half-maximal inhibitory concentration: 9270 nM
Beside the measured number, compound 4's estimate is 1.9-fold (0.29 log units) below it; the whole stated range lies below it.
By their numbers in this assay, from the lowest: compounds 3, 2, 1 and 4 (each within the scatter of the next, the first and the last beyond it).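

In this assay, among these compounds, the change from 4-(trifluoromethyl)phenyl to 4-fluorophenyl gives the only step at this position beyond the scatter (a 2.4-fold higher number from compound 3 to compound 4 (0.38 log units; beyond the scatter)), so the group on this aromatic carbon can matter. Fluoro does not separate from methyl (a 1.7-fold higher number from compound 2 to compound 4 (0.22 log units; within the scatter)) or from hydrogen (a 1.4-fold higher number from compound 1 to compound 4 (0.15 log units; within the scatter)), so compound 4 stands apart from compound 3 alone. No measurement at hand accounts for this step.

Going by these compounds, whether an amine, a carboxylic acid or a methoxy group at this place would move the number further remains open. So does whether this step would hold with other groups elsewhere on the shared core.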